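This account rests on a few compounds, and the source may have more. Where it says the series, first, only, none or still open, it means among the compounds named here.

Compound 1, `CCCC(=O)Nc1cccc(Oc2cccc(OC)c2)c1`: in an assay on isolated protein for binding affinity to melatonin receptor type 1A (Homo sapiens) (on this read-out higher numbers stand for weaker inhibition and lower numbers for stronger inhibition), compound 1 gives > 500 nM, which is a limit of the assay and not a number.
Compound 2, `CCCC(=O)Nc1ccc(Oc2ccc(OC)cc2)cc1`: in this assay compound 2 gives > 500 nM, again a limit and not a number.
Compound 3, `COc1cccc(Oc2ccc(NC(C)=O)cc2)c1`: in this assay compound 3 gives 84 nM.

Compound 3 therefore stands alone as the only one of the three with a numerical value in this assay. Within the data shown here, the other two sit at the limit of > 500 nM in this assay, at which 2 of the 3 values shown sit, so how far compound 3 lies from them cannot be said; only that their values are limits.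

Compound 4, `COc1cccc(Oc2ccc(NC(=O)C3CC3)cc2)c1`, has not been measured. It differs from compound 3 by cyclopropyl in place of methyl on a carbonyl carbon. Among the measured compounds shown here, no step between measured compounds covers this change, so nothing in the data fixes its size or direction. A small step in this assay is expected, one that may well stay within the usual scatter, with a slight lean toward stronger binding.

Compound 4 is thus estimated to give 60 nM, within a range from 20 nM to 200 nM. The expected step is a 1.4-fold lower number from compound 3 to compound 4 (0.15 log units; within the scatter).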

Compound 4, inhibition constant: 99 nM
For compound 4 the middle estimate is 1.7-fold (0.22 log units) below the measured one; measured number inside the range.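

Cyclopropyl in place of methyl on a carbonyl carbon gives a 1.2-fold higher number from compound 3 to compound 4 (0.07 log units; within the scatter) in this assay, so the two values lie within the usual scatter of each other. Among these compounds, this is the first step that can be read as a number, and it shows that at this place, on the acyl side of the amide, the three-membered ring and its larger count of heavy atoms are tolerated with binding kept at the level of compound 3. Nothing in the data given here speaks to why this is so.

Steps to compound 1 and compound 2 cannot be read: their values are limits and not numbers. As far as these compounds go, whether a longer chain such as propyl, a phenyl ring or an amine on this carbonyl carbon would also be tolerated remains open.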